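The source may report more compounds than this note shows. Statements on the series, on what has been measured and on what is new or still open speak of the compounds shown alone.

Compound 1 `ClCc1ccc(Cn2cnc3c(Cl)ncnc32)cc1`: in a functional assay on SF-268 cells (Homo sapiens) for cytotoxicity, read by sulforhodamine B assay, with a stated time of 48 h (on this read-out higher numbers stand for lower toxicity in this test and lower numbers for higher toxicity in this test), compound 1 gives 9330 nM.
Compound 2 `Nc1nc(Cl)c2ncn(Cc3ccc(CCl)cc3)c2n1`: compound 2 gives 38900 nM.
Compound 3 `ClCc1ccccc1Cn1cnc2c(Cl)ncnc21`: compound 3 gives > 100000 nM, which is a limit of this assay and not a number.

Compound 2 arises from compound 1 by amino in place of hydrogen on an aromatic carbon, and this gave a 4.2-fold higher number from compound 1 to compound 2 (0.62 log units; beyond the scatter). Compound 4 `Nc1nc(Cl)c2ncn(Cc3ccccc3CCl)c2n1`, not yet measured, arises from compound 3 by the same change, (amino in place of hydrogen on an aromatic carbon). How the core of compound 1 and the core of compound 3 differ is not broken down here. Compound 3 already sits at the limit of > 100000 nM in this assay, at which 1 of the 3 values shown sits. Because the earlier step of a 4.2-fold higher number from compound 1 to compound 2 (0.62 log units; beyond the scatter) moved the number higher, compound 4 is expected to stay at or beyond that limit, so the estimated step is a step that the limit leaves unreadable from compound 3 to compound 4. The estimate for compound 4 is 300000 nM, between 100000 nM and 1000000 nM.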

Compound 4, concentration lethal to 50% of the cells: 97200 nM
Estimate against measurement, compound 4: 3.1-fold (0.49 log units) above, outside the stated range (below it).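

In this assay, adding the amino group gives an at least 1.0-fold lower number from compound 3 to compound 4 (0.01 log units; that floor lies within the scatter), and this step does not match the one seen on the other core: the same change on two cores in this assay, a 4.2-fold higher number (0.62 log units; beyond the scatter) from compound 1 to compound 2 and an at least 1.0-fold lower number (0.01 log units; that floor lies within the scatter) from compound 3 to compound 4, at least 4.2-fold (0.63 log units) apart, beyond the scatter of two such steps

Compound 3 gives > 100000 nM, which is a limit of the assay and not a number. Going by these compounds alone, the change therefore does not carry a fixed shift from one core to the other, but with only two pairs and a limit in one of them, the true size of the second step stays unknown, and no rule for the series follows.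

The compounds shown leave open which difference between the core of compound 1 and the core of compound 3 sets the two steps apart. They also leave open how a methylamino or a hydroxyl group in place of the amino would behave on either core.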